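The source may hold more compounds than are shown below. What is called first, only, known or untested is meant among the compounds shown, and "the series" means these compounds.

Measured so far:
compound 1 `CCN(CC)Cc1ccc(S(=O)(=O)NCc2ccc(CNC(=O)c3ccc(F)cc3)cc2)cc1`: 1 nM
compound 2 `Cc1ccccc1S(=O)(=O)NCc1ccc(CNC(=O)c2ccc(F)cc2)cc1`: 100 nM
compound 3 `Cc1ccc(S(=O)(=O)NCc2ccc(CNC(=O)c3ccc(F)cn3)cc2)cc1`: 1000 nM

In an assay on MDA-MB-231 cells for binding affinity to C-X-C chemokine receptor type 4 (Homo sapiens), read by fluorescence and microscopy, with stated times of 10 min and 30 min (on this read-out lower numbers stand for an effect already at smaller amounts and higher numbers for an effect only at larger amounts of compound), compound 2 gives 100 nM, the second highest of the three numbers; compound 3 at 1000 nM sits higher and compound 1 at 1 nM sits lower, both gaps beyond the scatter. For the measured compounds named here, no single-point step between measured compounds is available, so nothing about a methyl-to-fluoro exchange has yet been observed.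

Compound 4 `O=C(NCc1ccc(CNS(=O)(=O)c2ccccc2F)cc1)c1ccc(F)cc1` differs from compound 2 by fluoro in place of methyl on an aromatic carbon. Going by the values given here, with no measured precedent for this change, the expectation in this assay is for a step of no more than the scatter in either direction, so the step from compound 2 to compound 4 is estimated as no change at the digits printed from compound 2 to compound 4 (within the scatter). Compound 4 is therefore expected at 100 nM, within 30 nM to 300 nM.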

Compound 4, effective concentration (reported as EC, without a stated level of effect): 10 nM
Beside the measured number, compound 4's estimate is 10-fold (1.00 log units) above it; measured number below the stated range.
By their numbers in this assay, from the lowest: compound 1; then compound 4; then compound 2; then compound 3.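

In this assay, replacing 2-methylphenyl with 2-fluorophenyl gives a 10-fold lower number from compound 2 to compound 4 (1.00 log units; beyond the scatter). For the compounds shown here, this is the first single-point step, and it shows that the number responds to a change on this aromatic carbon, ortho to a large group, with fluoro giving the lower number in this one pair. Nothing measured here accounts for the step. Still open, on these data alone, is whether chloro, methoxy or an amine at this place would follow fluoro or methyl. A single pair also leaves open whether the step carries over to other parts of the series.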